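The source may report more compounds than this note shows. Statements on the series, on what has been measured and on what is new or still open speak of the compounds shown alone.

In a functional assay on FaDu cells (Homo sapiens) for cytotoxicity, read by MTT assay, with a stated time of 72 h (a higher number here means that more compound is tolerated, a lower number that less compound is tolerated), compound 3 (`COc1ccc(NC(=O)C(=O)c2cn(C(C)C)c3ccccc23)cc1`) gives 181 nM. Compound 2 (`CCn1cc(C(=O)C(=O)Nc2ccc(OC)nc2)c2ccccc21`) gives 219 nM, which lies within the usual scatter of compound 3. Compound 1 (`COc1ccc(NC(=O)C(=O)c2cn(C(C)C)c3c(Cl)cccc23)cn1`) gives 10200 nM, far beyond that scatter. Compound 4 (`COc1ccc(NC(=O)C(=O)c2cn(C(C)C)c3ccccc23)cn1`) has 6-methoxypyridin-3-yl in place of 4-methoxyphenyl on an amide-type nitrogen. For the measured compounds named here, no measured pair shows this change alone, so the evidence is indirect. Compound 2 carries the same 6-methoxypyridin-3-yl and gives 219 nM, which supports a small step. Compound 1 also carries it and goes against that reading, with 10200 nM. In this assay, no step beyond the scatter is expected, and the estimate amounts to a 1.1-fold higher number from compound 3 to compound 4 (0.04 log units; within the scatter). Compound 4 is estimated at 200 nM, with an expected range of 70 nM to 600 nM.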

Compound 4, concentration lethal to 50% of the cells: 85 nM
The estimate for compound 4 lay 2.4-fold (0.37 log units) above the measured number, and the stated range covers the measured number.
By their numbers in this assay, from the lowest: compound 4; then compounds 3 and 2 (each within the scatter of the next); then compound 1.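

For the compounds shown here, compound 4 gives the first direct reading of this change on an amide-type nitrogen: in this assay, 6-methoxypyridin-3-yl in place of 4-methoxyphenyl brings a 2.1-fold lower number from compound 3 to compound 4 (0.33 log units; beyond the scatter). With that group held fixed, methyl in place of hydrogen on the saturated chain carbon bound to the aromatic nitrogen brings a 2.6-fold lower number from compound 2 to compound 4 (0.41 log units; beyond the scatter), while hydrogen in place of chloro on an aromatic carbon brings the largest step, a 120-fold lower number from compound 1 to compound 4 (2.08 log units; beyond the scatter). No measurement shown explains these steps. Going by these compounds, how a longer chain on the aromatic nitrogen, or an amine in place of methoxy, would shift the number remains open.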